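This account rests on a few compounds, and the source may have more. Where it says the series, first, only, none or still open, it means among the compounds named here.

Measured so far in an ADME assay on HEp-2 cells (Homo sapiens) for cytotoxicity, read by CCK-8 assay, with a stated time of 5 days; on this read-out higher numbers stand for lower toxicity in this test and lower numbers for higher toxicity in this test:
Compound 1 `Cc1ccc2nc(N3CCCc4ccc(F)cc4C3)cc(NCC3(N)COC3)c2c1` gives > 100000 nM, a limit of the assay.
Compound 3 `Cc1ccc2nc(N3CCCc4cc(F)ccc4C3)cc(NCCN)c2c1` gives > 3200 nM, also a limit of the assay.
Compound 2 `NCC(O)CNc1cc(N2Cc3ccccc3C2)nc2ccccc12` gives 2900 nM.

Compound 1 thus stands at the less toxic end of what this assay has reported, at the limit of > 100000 nM in this assay, at which 1 of the 3 values shown sits. Compound 4 `Cc1ccc2nc(N3CCCc4ccc(F)cc4C3)cc(NC(C)(C)CN)c2c1` differs from compound 1 in one place: 1-(aminomethyl)-1-methylethyl in place of (3-aminooxetan-3-yl)methyl on a nitrogen on an aromatic ring; in words, 1-(aminomethyl)-1-methylethyl in place of (3-aminooxetan-3-yl)methyl on a nitrogen on an aromatic ring. Among the compounds with values here, no two measured compounds differ in a single place, so no measured step guides this change. The step from compound 1 to compound 4 is expected to be an at least 1.6-fold lower number from compound 1 to compound 4 (0.22 log units; that floor lies within the scatter), a change not clearly beyond the usual scatter, though the limit leaves the starting point uncertain. Compound 4 is estimated at 60000 nM, with a range from 15000 nM to 150000 nM.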

Compound 4, half-maximal cytotoxic concentration: 25000 nM
Estimate against measurement, compound 4: 2.4-fold (0.38 log units) above; the measured number falls inside the stated range.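

In this assay, putting 1-(aminomethyl)-1-methylethyl in place of (3-aminooxetan-3-yl)methyl on this nitrogen gives an at least 4.0-fold lower number from compound 1 to compound 4 (0.60 log units; beyond the scatter). Within the data shown here, this is the first single-place comparison, and it shows that the group at this position can shift the read-out towards higher toxicity in this test while the rest of the structure stays the same. The value for compound 1 is a limit, so the true step may be larger: the limit of > 100000 nM in this assay, at which 1 of the 4 values shown sits.

The compounds shown do not tell whether losing the four-membered ring or its oxygen drives this step. A cyclobutyl ring carrying the same amine could separate the two.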